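Changing the group on the carbonyl of compound 3

This account rests on a few compounds, and the source may have more. Where it says the series, first, only, none or still open, it means among the compounds named here.

Measured in a functional assay on Caco-2 cells (Homo sapiens) for antiproliferative activity, read by MTT assay, with a stated time of 48 h; a lower number here means a stronger inhibitor, a higher number a weaker inhibitor
Compound 1 `CCn1c(C(=O)NCCN(C)C)ccc1C(CC)(CC)c1ccc(OCCC(O)(CC)CC)c(C)c1` gives 1140 nM
Compound 2 `CCn1c(C(=O)N(CCC#N)CCC#N)ccc1C(CC)(CC)c1ccc(OCCC(O)(CC)CC)c(C)c1` gives > 50000 nM as a limit, not a number
Compound 3 `C=CCN(C)C(=O)c1ccc(C(CC)(CC)c2ccc(OCCC(O)(CC)CC)c(C)c2)n1CC` gives > 50000 nM as a limit, not a number

From the compounds shown here alone, compound 3 stands at the limit of > 50000 nM in this assay, at which 2 of the 3 values shown sit, so its true value is unknown. Compound 4 (`C#CCCOC(=O)c1ccc(C(CC)(CC)c2ccc(OCCC(O)(CC)CC)c(C)c2)n1CC`) carries (but-3-yn-1-yl)oxy in place of allyl(methyl)amino on a carbonyl carbon, and (but-3-yn-1-yl)oxy in place of allyl(methyl)amino on a carbonyl carbon is the full count of that change. Going by the values given here, the steps that bear on it are changes on the same carbonyl carbon. The data show an at least 43-fold higher number from compound 1 to compound 2 (1.64 log units; beyond the scatter) and an at least 43-fold higher number from compound 1 to compound 3 (1.64 log units; beyond the scatter) both large and beyond the scatter. The remaining comparison is a step that the two limits leave unreadable from compound 2 to compound 3 and adds nothing. In both large steps the (2-(dimethylamino)ethyl)amino group of compound 1 was lost, and compound 4 lacks it too. Three compounds are thin support, but compound 4 is expected to stay with compound 3. The expected move is a number no higher from compound 3 to compound 4 (the limit leaves the size open) and no step beyond the scatter is expected in this assay. Compound 4 is estimated at 50000 nM with an expected range from 15000 nM to 100000 nM and may well give only a limit again.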

Compound 4, half-maximal inhibitory concentration: > 50000 nM
Compound 4: no number, only a limit; the forecaster's own chance of this, stated with the estimate: 75%; the middle value lies on the limit itself.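

In this assay, every earlier group on this carbonyl carbon was attached through nitrogen, and (but-3-yn-1-yl)oxy, attached through oxygen, gives an at least 43-fold higher number from compound 1 to compound 4 (1.64 log units; beyond the scatter). Going by these compounds alone, compound 1 therefore remains the only compound of the four with a measured number and the only one carrying (2-(dimethylamino)ethyl)amino, and this now holds against an oxygen-attached group as well as nitrogen-attached ones. The steps among compound 2, compound 3 and compound 4 cannot be read, since all three values are limits and not numbers: the limit of > 50000 nM in this assay, at which 3 of the 4 values shown sit.

From the compounds shown here alone, how far each of these three compounds lies past the limit remains unknown. Also open, going by these compounds, is whether a carboxylic acid on this carbonyl carbon, or a longer chain ending in a dimethylamino group, would give a measurable number.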